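Going from a cyclobutyl to an isopentyl on ring nitrogen

The source may report more compounds than this note shows. Statements on the series, on what has been measured and on what is new or still open speak of the compounds shown alone.

Measured so far:
compound 1 `O=C(O)c1cc(-c2cccc(COc3ccc4c(=O)n(CC5CC5)sc4c3)c2)ccc1Cl` – 2480 nM
compound 2 `O=C(O)c1cc(-c2cccc(COc3ccc4c(=O)n(C5CCC5)sc4c3)c2)ccc1Cl` – 580 nM

Within the data shown here, compound 2 `O=C(O)c1cc(-c2cccc(COc3ccc4c(=O)n(C5CCC5)sc4c3)c2)ccc1Cl` gives the lowest number of the two in an assay on HEK293 cells for positive allosteric modulation of metabotropic glutamate receptor 2 (Rattus norvegicus), read by thallium flux (on this read-out higher numbers stand for an effect only at larger amounts of compound and lower numbers for an effect already at smaller amounts), with compound 1 as its only neighbour; the step of a 4.3-fold lower number from compound 1 to compound 2 (0.63 log units; beyond the scatter) sets the two apart. Compound 3 `CC(C)CCn1sc2cc(OCc3cccc(-c4ccc(Cl)c(C(=O)O)c4)c3)ccc2c1=O` is reached by the change (isopentyl in place of cyclobutyl on an aromatic nitrogen). Among the measured compounds shown here, the one step that bears on this is the exchange from compound 1 to compound 2, which swapped one small carbon group for another on the same ring nitrogen and moved the number by a modest amount. Here the ring is lost and an open chain enters, a change of similar kind but not the same, so the number is expected to move modestly, most likely upward, in this assay. For compound 3 the estimated value is 1300 nM, between 400 nM and 4500 nM, which means an expected step of a 2.2-fold higher number from compound 2 to compound 3 (0.35 log units; beyond the scatter).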

Compound 3, half-maximal effective concentration: 650 nM
The estimate for compound 3 lay 2.0-fold (0.30 log units) above the measured number, and the stated range covers the measured number.
By their numbers in this assay, from the lowest: compounds 2 and 3 (each within the scatter of the next); then compound 1.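

In this assay, the change shows a 1.1-fold higher number from compound 2 to compound 3 (0.05 log units; within the scatter), so on this aromatic nitrogen an open isopentyl chain with no ring gives a number that cannot be told apart from that of the cyclobutyl group. The change also gives a 3.8-fold lower number from compound 1 to compound 3 (0.58 log units; beyond the scatter), which means that compound 1, not the open chain, stands apart, and that having a ring in this group does not by itself sort these three compounds, since compound 1 and compound 2 both carry one and compound 3 has none. Nothing available explains why the cyclopropylmethyl group gives the higher number.

Still open, as far as these compounds go, is whether a longer chain such as n-hexyl, or a benzyl group, would keep the number near those of compound 2 and compound 3. From the compounds shown here alone, it is equally open whether an amine or a hydroxyl at the end of the chain would change the number.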